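A few compounds are considered here, and "the series" means these few. Any claim that something is new, unique, unknown or untested is made for them only; others in the source may bear on it.

Values measured in a physicochemical assay for lipophilicity; a higher number here means a more lipophilic compound, a lower number a more polar compound:
- compound 1 `COc1ccc(C2=NO[C@]3(C2)C(=O)O[C@@H]2[C@H]3CC[C@H](C)[C@]3(O)C=CC(=O)[C@@]23C)cc1`: 1.47
- compound 2 `C[C@H]1CC[C@@H]2[C@@H](OC(=O)[C@]23CC(c2ccccc2[N+](=O)[O-])=NO3)[C@]2(C)C(=O)C=C[C@@]12O`: 1.37
- compound 3 `C[C@H]1CC[C@@H]2[C@@H](OC(=O)[C@]23CC(c2ccc(Cl)cc2)N(c2ccccc2)O3)[C@]2(C)C(=O)C=C[C@@]12O`: 3.87

Compound 3, at 3.87, stands highest of the three, beyond the scatter of both others. Compound 4 `Cc1ccccc1C1C[C@@]2(ON1c1ccccc1)C(=O)O[C@@H]1[C@H]2CC[C@H](C)[C@]2(O)C=CC(=O)[C@@]12C` differs from it by 2-methylphenyl in place of 4-chlorophenyl on a saturated ring carbon, with 2-methylphenyl in place of 4-chlorophenyl on a saturated ring carbon. Within the data shown here, no measured step makes this exact exchange. The nearest evidence is a number 0.10 log units lower from compound 1 to compound 2 (within the scatter), where 2-nitrophenyl takes the place of 4-methoxyphenyl on a carbon with a double bond to nitrogen. On that single precedent, no shift beyond the scatter is expected in this assay, and no firm direction. The expected step is a number 0.07 log units lower from compound 3 to compound 4 (within the scatter). For compound 4 the estimated value is 3.8, with an expected range from 3.4 to 4.2.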

Compound 4, partition coefficient: 3.64
Estimate against measurement, compound 4: 0.16 log units above; the measured number falls inside the stated range.
By their numbers in this assay, from the lowest: compounds 2 and 1 (each within the scatter of the next); then compounds 4 and 3 (each within the scatter of the next).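

In this assay the exchange of 4-chlorophenyl for 2-methylphenyl on this saturated ring carbon gives a number 0.23 log units lower from compound 3 to compound 4 (within the scatter) and so leaves no shift beyond the scatter. Among these compounds, the one earlier aryl exchange lay on a carbon with a double bond to nitrogen, so this is the first such reading at this position, where a chlorine-bearing group gives way to one of carbon only. Nothing measured here offers a reason for the result. From the compounds shown here alone, whether an amine or a carboxylic acid in place of the 2-methylphenyl would move the number beyond the scatter stays open. So does the effect of an exchange at the ring atom that bears a phenyl group.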